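This account rests on a few compounds, and the source may have more. Where it says the series, first, only, none or still open, it means among the compounds named here.

Three compounds of a shared core, each carrying a 2-hydroxyphenyl group, have been tested in a functional assay on HCT-15 cells (Homo sapiens) for cytotoxicity, read by CCK-8 assay; a lower number here means a stronger inhibitor, a higher number a weaker inhibitor. Compound 1 `Oc1ccc(-c2cc(-c3cccs3)cc(-c3ccccc3O)n2)cc1` gives only the limit of the assay, > 50000 nM, and no number. Compound 2 `Oc1ccc(-c2cc(-c3ccoc3)cc(-c3ccccc3O)n2)cc1` likewise stops at the limit, > 50000 nM. Compound 3 `Oc1ccccc1-c1cc(-c2ccccn2)cc(-c2ccccc2O)n1` also reaches only the limit, > 50000 nM. Among the compounds with values here, the one step between measured compounds that differ in a single place, a step that the two limits leave unreadable from compound 1 to compound 2, has no readable size because of the limit of > 50000 nM in this assay, at which 3 of the 3 values shown sit.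

The step followed here leads from compound 3 to compound 4 `Oc1ccc(-c2cc(-c3ccccn3)cc(-c3ccccc3O)n2)cc1`, which has not yet been measured. The change is 4-hydroxyphenyl in place of 2-hydroxyphenyl on an aromatic carbon. Within the data shown here, no measured step concerns this swap of a hydroxyphenyl group: the only step on record, from compound 1 to compound 2, touches a different position and is itself unreadable. What remains is that every value shown sits at the limit, so a reading below the limit for compound 4 would be a departure from all three measured compounds. The expected step, a step that the limit leaves unreadable from compound 3 to compound 4, is therefore none that the numbers can show. Compound 4 is estimated at 60000 nM in this assay, within a range from 15000 nM to 250000 nM, most likely reported again as a limit.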

Compound 4, half-maximal inhibitory concentration: > 50000 nM
Compound 4 gave a limit, no number (the forecaster's own chance of this, stated with the estimate: 80%); the middle value is on the limit's open side.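

In this assay compound 4 gives > 50000 nM, a limit and not a number. Its steps from compound 1, compound 2 and compound 3 cannot be read, because all the compounds end the same way: the limit of > 50000 nM in this assay, at which 4 of the 4 values shown sit. The compounds shown leave open whether 4-hydroxyphenyl in place of 2-hydroxyphenyl, or any other swap here, changes the potency at all.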